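The compounds below may be only part of what the source reports. "The series", "measured", "known", "first", "only" and "open" are said of these compounds alone.

Measured compounds:

Compound 1, `O=C(/C=C/c1ccc(OCCCCCO[N+](=O)[O-])c(O)c1)OCCCCCO[N+](=O)[O-]`: 5730 nM
Compound 2, `O=C(/C=C/c1ccc(OCCCCO[N+](=O)[O-])c(O)c1)OCCCCO[N+](=O)[O-]`: 3930 nM
Compound 3, `COc1cc(/C=C/C(=O)OCCCCCO[N+](=O)[O-])ccc1OCCCCCO[N+](=O)[O-]`: > 50000 nM

These three compounds were tested in a functional assay on HeLa cells (Homo sapiens) for cytotoxicity, read by resazurin assay, with a stated time of 72 h; a higher number here means a weaker inhibitor, a lower number a stronger inhibitor. In this assay compound 1 gives 5730 nM and compound 2 gives 3930 nM; the two values lie within the scatter of each other, so neither can be called the more potent. Compound 3 reaches only (the limit of > 50000 nM in this assay, at which 1 of the 3 values shown sits), which is a limit of the assay and not a number.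

Compound 1 and compound 3 differ in one place: methyl in place of hydrogen on an oxygen on an aromatic ring. This change brought an at least 8.7-fold higher number from compound 1 to compound 3 (0.94 log units; beyond the scatter). How compound 1 and compound 2 differ is not broken down here.

Compound 4, `COc1cc(/C=C/C(=O)OCCCCO[N+](=O)[O-])ccc1OCCCCO[N+](=O)[O-]`, has not been measured. It stands to compound 2 as compound 3 stands to compound 1: methyl in place of hydrogen on an oxygen on an aromatic ring. The place of the change reads the same in both pairs, so this is the same kind of change on a core that differs only by its chains.

Among the measured compounds shown here, for compound 4 the expected step is a 15-fold higher number from compound 2 to compound 4 (1.18 log units; beyond the scatter), resting on the step of an at least 8.7-fold higher number from compound 1 to compound 3 (0.94 log units; beyond the scatter) in this assay, which is the only example of this change at hand. Because compound 3 sits at the limit of > 50000 nM in this assay, at which 1 of the 3 values shown sits, a limit rather than a number is a real possibility for compound 4 as well. Compound 4 is therefore expected to give about 60000 nM in this assay, with a likely range from 20000 nM to 300000 nM.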

Compound 4, half-maximal inhibitory concentration: 740 nM
Beside the measured number, compound 4's estimate is 81-fold (1.91 log units) above it; the whole stated range lies above it.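

The hydroxy to methoxy change gave a 5.3-fold lower number from compound 2 to compound 4 (0.73 log units; beyond the scatter) in this assay, while the same change pushed the number up on the other core, so the two results disagree even in direction: the same change on two cores in this assay, an at least 8.7-fold higher number (0.94 log units; beyond the scatter) from compound 1 to compound 3 and a 5.3-fold lower number (0.73 log units; beyond the scatter) from compound 2 to compound 4, at least 46-fold (1.66 log units) apart, beyond the scatter of two such steps. The earlier result rests on compound 3, whose value is a limit of the assay and not a number: the limit of > 50000 nM in this assay, at which 1 of the 4 values shown sits. This shows that the effect of this change did not carry from one core to the other in this series, even though the two cores differ only by their chains, but with a single pair on each core it does not show why, and it gives no rule for predicting the change on any further core.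

The compounds shown leave open whether the chains really decide the direction of the step, which a longer chain carrying first a hydroxy and then a methoxy group on the ring could test. They also leave open how a larger group such as ethoxy, or an amine, would behave in the same place on the aromatic ring, and how far the two steps truly lie apart, since one of them ends at a limit.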